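A few compounds are considered here, and "the series" means these few. Any claim that something is new, unique, unknown or untested is made for them only; others in the source may bear on it.

Compound 1, `CCOc1cccc(-c2ccc(CN(C(=O)C3CCCCC3)c3cccc(/C=C/C(=O)OC)c3)cc2)c1`, gives in an assay on isolated protein with Bile acid receptor (Homo sapiens) as the target (on this read-out lower numbers stand for an effect already at smaller amounts and higher numbers for an effect only at larger amounts of compound), a value of 147 nM.
Compound 2, `COC(=O)/C=C/c1ccc(CN(C(=O)C2CCCCC2)c2cccc(/C=C/C(=O)OC)c2)cc1`, gives in this assay only > 1000 nM, which is a limit of the assay and not a number.
Compound 3, `COC(=O)/C=C/c1cccc(N(Cc2ccc(/C=C/C(=O)OC(C)(C)C)cc2OCc2ccccc2)C(=O)C2CCCCC2)c1`, gives in this assay only > 1000 nM, again a limit of the assay rather than a number.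

Compound 3 therefore stands at the limit of > 1000 nM in this assay, at which 2 of the 3 values shown sit, together with compound 2, while compound 1 alone has a number below that limit. Compound 4, `COC(=O)/C=C/c1cccc(N(Cc2ccc(/C=C/C(=O)OC(C)(C)C)cc2O)C(=O)C2CCCCC2)c1`, has not yet been measured in this assay. It differs from compound 3 in one place: hydrogen in place of benzyl on an oxygen on an aromatic ring, so that the benzyloxy group of compound 3 becomes a hydroxy group in compound 4. Among the compounds with values here, only one measured step connects two of the compounds that differ in a single place, an at least 6.8-fold higher number from compound 1 to compound 2 (0.83 log units; beyond the scatter), and that step exchanges a group on an aromatic carbon, not a substituent on an oxygen, so it does not speak to the change from compound 3 to compound 4. With compound 3 at a limit, the step is expected to run as a step that the limit leaves unreadable from compound 3 to compound 4, with a fair chance that compound 4 also returns only a limit. Compound 4 is expected to give about 1500 nM, within a range from 300 nM to 8000 nM.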

Compound 4, half-maximal effective concentration: > 1000 nM
Compound 4: no number, only a limit; the forecaster's own chance of this, stated with the estimate: 55%; the middle value does not contradict the limit.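

In this assay compound 4 gives only > 1000 nM and this is a limit of the assay, not a number. Compound 3 sits at the same limit, so no step can be read between compound 3 and compound 4: the limit of > 1000 nM in this assay, at which 3 of the 4 values shown sit. The compounds shown leave open whether changing benzyloxy to hydroxy alters the value at all.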